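Cyclopentyl for butyl on an aminoimidazole anilide core

The source may report more compounds than this note shows. Statements on the series, on what has been measured and on what is new or still open speak of the compounds shown alone.

Compound 1 `CCCCCc1nc(N)n(CC(=O)Nc2ccccc2)c1-c1ccccc1Br`: 26400 nM
Compound 2 `Cc1ccc(Cc2nc(N)n(CC(=O)Nc3ccccc3)c2-c2ccccc2Br)cc1`: 2500 nM
Compound 3 `CCCCCc1nc(N)n(CC(=O)Nc2ccc(C)cc2)c1-c1ccccc1Br`: 4300 nM

All three compounds were tested in a functional assay on A-375 cells (Homo sapiens) for antiproliferative activity, read by MTT assay, with a stated time of 48 h; on this read-out higher numbers stand for weaker inhibition and lower numbers for stronger inhibition. Compound 3 gives 4300 nM, the second highest of the three numbers; its nearest neighbour is compound 2, a difference within the scatter, while compound 1 lies furthest away, beyond the scatter. The unmeasured compound 4 `Cc1ccc(NC(=O)Cn2c(N)nc(CC3CCCC3)c2-c2ccccc2Br)cc1` keeps the methyl of compound 3 and changes the chain: cyclopentyl in place of butyl on a saturated chain carbon bound to an aromatic carbon.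

For the measured compounds named here, only one measured step touches that same place: an 11-fold lower number from compound 1 to compound 2 (1.02 log units; beyond the scatter), where a ring also replaced the butyl, though that ring was 4-methylphenyl rather than cyclopentyl. The other step, a 6.1-fold lower number from compound 1 to compound 3 (0.79 log units; beyond the scatter), concerns the methyl that compound 3 and compound 4 share and says nothing about the chain. With one related step of large size but a different entering group, a modest step downward in this assay is expected for compound 4, a 2.4-fold lower number from compound 3 to compound 4 (0.38 log units; beyond the scatter). Compound 4 is therefore estimated at 1800 nM, with a range from 600 nM to 5500 nM.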

Compound 4, half-maximal inhibitory concentration: 47800 nM
Compound 4: middle estimate off by 27-fold (1.42 log units), on the low side; the measured number lies above the stated range.
By their numbers in this assay, from the lowest: compounds 2 and 3 (each within the scatter of the next); then compounds 1 and 4 (each within the scatter of the next).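

In this assay, replacing butyl with a ring at this position does not lower the number by itself. 4-Methylphenyl gave an 11-fold lower number from compound 1 to compound 2 (1.02 log units; beyond the scatter), whereas cyclopentyl gave an 11-fold higher number from compound 3 to compound 4 (1.05 log units; beyond the scatter), a step of similar size in the opposite direction. The two steps start from different anilides, the second carrying the methyl, so they show that the outcome depends on the change as a whole, not simply on the arrival of a ring; no available evidence explains the rise with cyclopentyl.

The compounds shown leave open whether this rise belongs to cyclopentyl alone or would also appear with a cyclohexyl or an unsubstituted phenyl at the same place. They also leave open how 4-methylphenyl behaves when combined with the methyl of compound 3.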